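Side-chain size at the amine-bearing carbon of compound 2

The source may report more compounds than this note shows. Statements on the series, on what has been measured and on what is new or still open speak of the compounds shown alone.

Compound 1 `CC(C)[C@H](NCCC1OCC(C)(C)CO1)C(=O)N[C@H]1C(O)O[C@H](CO)[C@@H](O)[C@@H]1O`: 85.1%
Compound 2 `C[C@H](NCCC1OCC(C)(C)CO1)C(=O)N[C@H]1C(O)O[C@H](CO)[C@@H](O)[C@@H]1O`: 86.8%

In a functional assay on the whole organism (Ear, strain ICR) for inhibition, with Mus musculus as the target, with stated times of 30 min and 2 h, at a dose of 10 umol/kg by the oral route (a higher number here means more inhibition at the dose given (going by the name of the read-out), a lower number less inhibition), compound 1 gives 85.1% and compound 2 gives 86.8%. Going by the values given here, the one measured step, a number 1.7 percentage points higher from compound 1 to compound 2 (within the scatter), lies within the scatter. Compound 2 stands at the higher of the two numbers, though its gap to compound 1 is within the scatter. Compound 3 `CC(C)C[C@H](NCCC1OCC(C)(C)CO1)C(=O)N[C@H]1C(O)O[C@H](CO)[C@@H](O)[C@@H]1O` differs from compound 2 by isopropyl in place of hydrogen on a saturated chain carbon, two bonds along the chain from an amine nitrogen and a carbonyl carbon. The step from compound 1 to compound 2 bears on this change, because a number 1.7 percentage points higher from compound 1 to compound 2 (within the scatter) shows that altering the side chain at this position changed little. Compound 3 is therefore expected to give 85% (range 72% to 93%), a step of a number 1.8 percentage points lower from compound 2 to compound 3 (within the scatter) that is expected to stay within the scatter.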

Compound 3, a percentage reported as inhibition, in the whole organism at one dose (the size of the read-out at that dose, not a potency): 81.8%
Compound 3: the middle estimate sits 3.2 percentage points above what was measured; measured number inside the range.
By their numbers in this assay, from the lowest: compounds 3, 1 and 2 (each within the scatter of the next).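

In this assay the larger isobutyl group gives a number 5 percentage points lower from compound 2 to compound 3 (within the scatter) and also a number 3.3 percentage points lower from compound 1 to compound 3 (within the scatter). Methyl, isopropyl and isobutyl on this saturated chain carbon therefore cannot be told apart at this single dose, and the range of groups that leaves the read-out within the scatter now extends to isobutyl. No evidence at hand bears on why this is so.

The compounds shown leave open whether a side chain carrying a phenyl ring, a carboxylic acid or an amine would read the same here. They also leave open whether these three compounds would separate at a lower dose.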